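The compounds below may be only part of what the source reports. "The series", "measured", "known", "first", "only" and "open" are said of these compounds alone.

Measured compounds:
compound 1 `CCCn1c(=O)n(CCN(C)C)c(=O)c2[nH]cnc21`, 4300 nM
compound 2 `CCCn1c(=O)n(C)c(=O)c2c1ncn2CCN(C)C`, > 200000 nM

In an assay on Cerebral cortex for binding affinity to adenosine receptor A1 (Cavia porcellus), read by radioligand binding (a higher number here means a weaker inhibitor, a lower number a stronger inhibitor), compound 1 gives 4300 nM. Compound 2 yields only a limit in this assay, > 200000 nM. That figure is the limit of > 200000 nM in this assay, at which 1 of the 2 values shown sits. Among the measured compounds shown here, compounds 1 and 2 differ in more than one place, so no single step connects them; their two values simply show that compound 1 registers a number while compound 2 does not.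

Compound 3 `CCCn1c(=O)n(C)c(=O)c2c1ncn2CC(C)=O` has not yet been measured in this assay. It is set apart from compound 2 by acetyl in place of (dimethylamino)methyl on a saturated chain carbon bound to an aromatic nitrogen. For the measured compounds named here, no measured step of this kind is available, so the size of the change must be guessed from compound 2 alone. Compound 2 sits at the limit, and compound 3 carries the same core with the same propyl and methyl groups, so the expectation is that the acetyl for (dimethylamino)methyl exchange moves the affinity little, with a step of an at least 1.3-fold lower number from compound 2 to compound 3 (0.12 log units; that floor lies within the scatter) expected to stay within the scatter. For compound 3 the estimated value in this assay is 150000 nM, ranging from 30000 nM to 600000 nM.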

Compound 3, inhibition constant: 95700 nM
Compound 3: middle estimate off by 1.6-fold (0.20 log units), on the high side; low and high end bracket the measured number.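

Putting acetyl in place of (dimethylamino)methyl on a saturated chain carbon bound to an aromatic nitrogen gives, in this assay, an at least 2.0-fold lower number from compound 2 to compound 3 (0.32 log units; beyond the scatter). Among the compounds shown here, this is the first readable step at this place: with the propyl and methyl groups and the shared core unchanged, the change from 2-(dimethylamino)ethyl to 2-oxopropyl alone turns a limit into a number, so the group carried here bears on the reading and the dimethylamino end is not needed for a measurable value. The true size of the step cannot be read, and the printed figure is only a minimum, because the value of compound 2 is a limit and not a number: the limit of > 200000 nM in this assay, at which 1 of the 3 values shown sits.

The compounds shown do not tell whether the step comes from gaining the carbonyl or from losing the amine, since both happen in the one exchange. On these data alone, a 2-hydroxypropyl group, a carboxylic acid or a plain longer alkyl chain at this place could separate the two, and how any of them would read against compound 3 remains open.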